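A few compounds are considered here, and "the series" means these few. Any claim that something is new, unique, unknown or untested is made for them only; others in the source may bear on it.

Compound 2, `O=C(Nc1cccc(CNc2nccnc2Cl)c1)Nc1ccccc1F`, holds the lower of the two numbers in a functional assay on MGC-803 cells (Homo sapiens) for antiproliferative activity, read by MTT assay, with a stated time of 48 h; a lower number here means a stronger inhibitor, a higher number a weaker inhibitor: compound 2 gives 6440 nM, while compound 1, `O=C(Nc1ccccc1)Nc1cccc(CNc2nccnc2Cl)c1`, gives 16300 nM. Going by the values given here, the single measured step, a 2.5-fold lower number from compound 1 to compound 2 (0.40 log units; beyond the scatter), was modest. Compound 3, `O=C(Nc1cccc(CNc2nccnc2Cl)c1)Nc1ccccc1Cl`, differs from compound 2 in one place: chloro in place of fluoro on an aromatic carbon. Among the compounds with values here, no measured step shows a chloro replacing a fluoro, so only the modest size of the fluoro step offers any guide. Compound 3 is therefore expected to land near compound 2, with a step of a 1.3-fold lower number from compound 2 to compound 3 (0.11 log units; within the scatter) that may well stay within the scatter. The estimate for compound 3 is 5000 nM, between 2200 nM and 12000 nM.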

Compound 3, half-maximal inhibitory concentration: 7130 nM
The estimate for compound 3 lay 1.4-fold (0.15 log units) below the measured number; the range from low to high includes it.
By their numbers in this assay, from the lowest: compounds 2 and 3 (each within the scatter of the next); then compound 1.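

In this assay, chloro and fluoro at this place on the aromatic ring, ortho to a large group, cannot be told apart, with a step of a 1.1-fold higher number from compound 2 to compound 3 (0.04 log units; within the scatter). Chloro in place of hydrogen gives a 2.3-fold lower number from compound 1 to compound 3 (0.36 log units; beyond the scatter), so the lower number seen with fluoro is not confined to that one halogen. No measurement at hand accounts for the two halogens reading alike. Going by these compounds, whether a methyl group, a methoxy group or an amine at this place would keep the number remains open, as does chloro on another carbon of this ring.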